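The compounds below may be only part of what the source reports. "The series", "measured", "known", "first", "only" and "open" are said of these compounds alone.

Working notes on the series. Among the measured compounds shown here, in an ADME assay on the whole organism (plasma, strain Sprague-Dawley) for pharmacokinetics, with Rattus norvegicus as the target (on this read-out lower numbers stand for slow clearance and higher numbers for fast clearance), compound 1 (`Nc1nc2c(s1)CC[C@H]2C(=O)Nc1ccc(C[C@@H]2CC[C@H]([C@H](O)c3ccccc3)N2)cc1`) gives 50 mL/min/kg and compound 2 (`Cc1nc2c(s1)CC[C@H]2C(=O)Nc1ccc(C[C@@H]2CC[C@H]([C@H](O)c3cccnc3)N2)cc1`) gives 25 mL/min/kg on the numbers so far. These two values lie within the scatter of each other, so compound 2 stands level with compound 1. Compound 3 (`Nc1nc2c(s1)CC[C@H]2C(=O)Nc1ccc(C[C@@H]2CC[C@H]([C@H](O)c3cccnc3)N2)cc1`) differs from compound 2 by amino in place of methyl on an aromatic carbon of a five-membered aromatic ring with 1 nitrogen and 1 sulfur. For the measured compounds named here, no measured step in this assay sizes this change, so no step beyond the scatter is expected. Amino is also carried by compound 1 at 50 mL/min/kg and that value gives the expectation only a slight upward lean. The estimated move is a 1.2-fold higher number from compound 2 to compound 3 (0.08 log units; within the scatter) and stays within the scatter. For compound 3 the expected value is 30 mL/min/kg with an estimated range from 14 mL/min/kg to 60 mL/min/kg for the measurement.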

Compound 3, clearance: 32 mL/min/kg
Estimate against measurement, compound 3: 1.1-fold (0.03 log units) below; measured number inside the range.
By their numbers in this assay, from the lowest: compounds 2, 3 and 1 (each within the scatter of the next).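

In this assay, among the compounds shown here, amino in place of methyl on an aromatic carbon of the five-membered aromatic ring with 1 nitrogen and 1 sulfur gives a 1.3-fold higher number from compound 2 to compound 3 (0.11 log units; within the scatter) and so supplies the first measured step at this position, one that does not leave the scatter. Pyridin-3-yl in place of phenyl on the saturated chain carbon bound to an oxygen gives a 1.6-fold lower number from compound 1 to compound 3 (0.19 log units; within the scatter) and also stays within the scatter, so neither single change separates these compounds on clearance. Nothing measured on these compounds bears on what lies behind either step.

Still open, going by these compounds, is whether another group on this aromatic carbon, such as a hydroxyl or an ethyl chain, would move clearance beyond the scatter. Equally open, on these data alone, is what a fluorine on the pyridin-3-yl ring would do.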